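Swapping the urea chain for a thiazole ring

The compounds below may be only part of what the source reports. "The series", "measured", "known", "first", "only" and "open" are said of these compounds alone.

Measured so far:
compound 1 `CCNc1nc(C)c(-c2nc3ccccc3s2)c(N[C@@H]2C[C@H](CO)[C@@H](O)[C@H]2O)n1` — in an ADME assay on cells (Homo sapiens) for cytotoxicity, read by polymerase chain reaction, with a stated time of 3 days (on this read-out lower numbers stand for higher toxicity in this test and higher numbers for lower toxicity in this test), compound 1 gives 12000 nM
compound 2 `Cc1nc(NCC2CC2)nc(N[C@@H]2C[C@H](CO)[C@@H](O)[C@H]2O)c1-c1nc2ccccc2s1` — compound 2 gives 8000 nM
compound 3 `Cc1nc(NCCNC(=O)NC(C)(C)C)nc(N[C@@H]2C[C@H](CO)[C@@H](O)[C@H]2O)c1-c1nc2ccccc2s1` — compound 3 gives > 25000 nM, which is a limit of the assay and not a number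

Compound 3 therefore sits at the least toxic end of the three values, described only by the limit of > 25000 nM in this assay, at which 1 of the 3 values shown sits. Among the measured steps, a 1.5-fold lower number from compound 1 to compound 2 (0.18 log units; within the scatter), whereas an at least 2.0-fold higher number from compound 1 to compound 3 (0.31 log units; beyond the scatter) and an at least 3.1-fold higher number from compound 2 to compound 3 (0.49 log units; beyond the scatter), both beyond the scatter.

Compound 4 `Cc1nc(Nc2nccs2)nc(N[C@@H]2C[C@H](CO)[C@@H](O)[C@H]2O)c1-c1nc2ccccc2s1` differs from compound 3 by 1,3-thiazol-2-yl in place of 2-(((tert-butyl)carbamoyl)amino)ethyl on a nitrogen on an aromatic ring. This removes the very chain whose arrival in compounds 1 and 2 raised the number beyond the scatter. Both steps bearing on the change thus point the same way once read backwards: without the chain, the number is expected to fall back toward where compounds 1 and 2 sit. Compound 4 is therefore estimated at 9000 nM, with a range from 2500 nM to 30000 nM, which is expected to mean an at least 2.7-fold lower number from compound 3 to compound 4 (0.44 log units; beyond the scatter).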

Compound 4, half-maximal cytotoxic concentration: 15000 nM
Beside the measured number, compound 4's estimate is 1.7-fold (0.22 log units) below it, and the stated range covers the measured number.
By their numbers in this assay, from the lowest: compounds 2, 1 and 4 (each within the scatter of the next). At a limit, above all of these: compound 3.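

In this assay, 1,3-thiazol-2-yl on the nitrogen gives a reading that cannot be told apart from those of the saturated groups there, with a 1.3-fold higher number from compound 1 to compound 4 (0.10 log units; within the scatter) against ethyl and a 1.9-fold higher number from compound 2 to compound 4 (0.27 log units; within the scatter) against cyclopropylmethyl. Going by these compounds alone, the earlier compounds held only saturated chains at this place, so this is the first sign that an aromatic ring can stand there without moving the number beyond the scatter. Replacing the urea chain gives an at least 1.6-fold lower number from compound 3 to compound 4 (0.22 log units; that floor lies within the scatter), and this is only a floor because compound 3 carries a limit of the assay and not a number: the limit of > 25000 nM in this assay, at which 1 of the 4 values shown sits.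

On these data alone, what remains open is whether this reading is particular to the 1,3-thiazol-2-yl ring or would hold for other rings on the same nitrogen. A phenyl or pyridyl ring, or a free primary amine there, would test how far it extends.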